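Changing the Outer Ring on a Weak Cell-Growth Inhibitor

This account rests on a few compounds, and the source may have more. Where it says the series, first, only, none or still open, it means among the compounds named here.

Compound 1 `Cc1cccc(NC(=O)Nc2cccc(CNc3ncnc4ccccc34)c2)c1` and compound 2 `O=C(Nc1cccc(CNc2ncnc3ccccc23)c1)Nc1ccccc1F` share one core and differ only in the ring attached to an amide-type nitrogen. Among the measured compounds shown here, in a functional assay on A549 cells (Homo sapiens) for antiproliferative activity, read by MTT assay (a lower number here means a stronger inhibitor, a higher number a weaker inhibitor), compound 1 gives 30200 nM, the highest of the two numbers measured so far, and compound 2 gives 26100 nM. The step of a 1.2-fold lower number from compound 1 to compound 2 (0.06 log units; within the scatter) shows that exchanging one ring for the other at this position barely moves the read-out. Compound 3 `O=C(Nc1ccc(F)cc1)Nc1cccc(CNc2ncnc3ccccc23)c1` is a further variation on compound 1: 4-fluorophenyl in place of 3-methylphenyl on an amide-type nitrogen. For the measured compounds named here, only one measured step bears on this change, a 1.2-fold lower number from compound 1 to compound 2 (0.06 log units; within the scatter), which likewise replaces the 3-methylphenyl with a fluorine-bearing ring on the same amide-type nitrogen. No step beyond the scatter is therefore expected in this assay. Compound 3 is estimated at 27000 nM, with a range from 12000 nM to 60000 nM. That estimate would mean an expected step of a 1.1-fold lower number from compound 1 to compound 3 (0.05 log units; within the scatter).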

Compound 3, half-maximal inhibitory concentration: 21000 nM
Estimate against measurement, compound 3: 1.3-fold (0.11 log units) above, and the stated range covers the measured number.
By their numbers in this assay, from the lowest: compounds 3, 2 and 1 (each within the scatter of the next).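

Compound 3 brings in a second fluorine-bearing ring, and the step of a 1.2-fold lower number from compound 2 to compound 3 (0.09 log units; within the scatter) shows that 4-fluorophenyl and 2-fluorophenyl on the amide-type nitrogen cannot be told apart in this assay. The step of a 1.4-fold lower number from compound 1 to compound 3 (0.16 log units; within the scatter) shows the same for 4-fluorophenyl against 3-methylphenyl, so all three outer rings now give numbers within the scatter of each other, and a fluorine-bearing ring offers no measurable gain over the methyl-bearing one. No other data are available that bear on this result.

Going by these compounds, each outer ring so far is a phenyl ring carrying a single methyl or fluorine, so it remains open whether an amine, a carboxylic acid or a longer chain on that ring would move the number beyond the scatter. On these data alone, it also remains open whether a change in the shared core itself would do so.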